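Ester Branching on Two Urea Cores in a Vasopressin Agonist Series

This account rests on a few compounds, and the source may have more. Where it says the series, first, only, none or still open, it means among the compounds named here.

Measured so far in a functional assay on HEK293 cells for agonist activity at Vasopressin V2 receptor (Homo sapiens), read by a luciferase reporter and cAMP accumulation; on this read-out higher numbers stand for an effect only at larger amounts of compound and lower numbers for an effect already at smaller amounts:
Compound 1, `Cc1cc(C(=O)N2CCCCc3ccccc32)ccc1CNC(=O)NCC(=O)OC(C)C`: 140 nM
Compound 2, `Cc1cc(C(=O)N2CCCCc3ccccc32)ccc1CNC(=O)NCC(=O)OC(C)(C)C`: 120 nM
Compound 3, `Cc1cc(C(=O)N2CCCCc3ccccc32)ccc1CNC(=O)N1CCC[C@H]1C(=O)OC(C)C`: 950 nM

Compounds 1 and 2 share a core and differ only at the ester end: methyl in place of hydrogen on a saturated chain carbon bound to an oxygen next to a carbonyl group and two saturated chain carbons. On this assay the step was a 1.2-fold lower number from compound 1 to compound 2 (0.07 log units; within the scatter), so the two numbers cannot be told apart. Compound 3 carries a different urea portion; the difference between its core and that of compound 1 is 2-(isopropoxycarbonyl)pyrrolidin-1-yl in place of ((isopropoxycarbonyl)methyl)amino on a carbonyl carbon. Here the step was a 6.8-fold higher number from compound 1 to compound 3 (0.83 log units; beyond the scatter), and against compound 2 it was a 7.9-fold higher number from compound 2 to compound 3 (0.90 log units; beyond the scatter), so compound 3 stands at the highest number of the three.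

Compound 4, `Cc1cc(C(=O)N2CCCCc3ccccc32)ccc1CNC(=O)N1CCC[C@H]1C(=O)OC(C)(C)C`, has not yet been measured. It differs from compound 3 by methyl in place of hydrogen on a saturated chain carbon bound to an oxygen next to a carbonyl group and two saturated chain carbons. This is the same change that turns compound 1 into compound 2, made at the same place on a compound whose core is that of compound 3.

The step for compound 4 is expected to be a 1.2-fold lower number from compound 3 to compound 4 (0.07 log units; within the scatter), because the same change earlier gave only a 1.2-fold lower number from compound 1 to compound 2 (0.07 log units; within the scatter). Whether the core of compound 3 responds in the same way is not known from these three compounds, so the range is kept wide. Compound 4 is therefore estimated at 800 nM in this assay. For compound 4 the expected span runs from 300 nM to 2500 nM.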

Compound 4, half-maximal effective concentration: 390 nM
Estimate against measurement, compound 4: 2.1-fold (0.31 log units) above; the measured number falls inside the stated range.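

In this assay, the methyl that turns isopropyl into tert-butyl gave a 2.4-fold lower number from compound 3 to compound 4 (0.39 log units; beyond the scatter) on the core of compound 3 and a 1.2-fold lower number from compound 1 to compound 2 (0.07 log units; within the scatter) on the core of compound 1, and the two results do not differ measurably: the same change on two cores in this assay, a 1.2-fold lower number (0.07 log units; within the scatter) from compound 1 to compound 2 and a 2.4-fold lower number (0.39 log units; beyond the scatter) from compound 3 to compound 4, 2.1-fold (0.32 log units) apart, within the scatter of two such steps. Within the data shown here, the change therefore carries over from one core to the other as far as these two pairs can tell, although only the step on the core of compound 3 lies beyond the scatter, and that contrast is not enough to say that this core responds more strongly. The tert-butyl ester does not erase the gap between the cores, since a 3.3-fold higher number from compound 2 to compound 4 (0.51 log units; beyond the scatter) and a 2.8-fold higher number from compound 1 to compound 4 (0.44 log units; beyond the scatter) are both beyond the scatter, but two pairs on two cores make no rule for the whole series.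

Still open, going by these compounds, is how other groups at the same place would behave on these two cores, such as an ethyl ester, a cyclohexyl ester or a free carboxylic acid. Also open, on these data alone, is whether the same change would carry over to a urea portion built on a longer chain or on a piperidine ring.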